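The source may report more compounds than this note shows. Statements on the series, on what has been measured and on what is new or still open speak of the compounds shown alone.

Compound 1 `O=c1c(CO)cc(-c2ccc(F)nc2F)nn1Cc1ccc(Cl)cc1`: > 100000 nM (a limit)
Compound 2 `O=C(O)c1cc(-c2ccc(F)nc2F)nn(Cc2ccc(Cl)cc2)c1=O`: > 100000 nM (a limit)

In an ADME assay on HepG2 2.2.15 cells (Homo sapiens) for cytotoxicity, read by MTT assay, with a stated time of 8 days (on this read-out higher numbers stand for lower toxicity in this test and lower numbers for higher toxicity in this test), compound 2 gives > 100000 nM, which is a limit of the assay and not a number. Among the measured compounds shown here, the same holds across the series so far: the limit of > 100000 nM in this assay, at which 2 of the 2 values shown sit. For the measured compounds named here, the only measured step is a step that the two limits leave unreadable from compound 1 to compound 2, so it offers no size to carry forward.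

Compound 3 `COc1cc(-c2ccc(F)nc2F)nn(Cc2ccc(Cl)cc2)c1=O` differs from compound 2 as follows: methoxy in place of carboxy on an aromatic carbon. In words, this is methoxy in place of carboxy on an aromatic carbon, opposite the ring nitrogen.

Going by the values given here, with the limit of > 100000 nM in this assay, at which 2 of the 2 values shown sit, as the sole guide, no step beyond the scatter is expected in this assay, and no direction can be favoured. The expected step is a number no higher from compound 2 to compound 3 (the limit leaves the size open). For compound 3 the estimated half-maximal cytotoxic concentration is 100000 nM, within an expected range from 40000 nM to 200000 nM.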

Compound 3, half-maximal cytotoxic concentration: 92200 nM
Compound 3: the middle estimate sits 1.1-fold (0.04 log units) above what was measured, within the range that was stated.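

In this assay, compound 3 is the only one of the three compounds shown to give a number rather than a limit of the assay, so methoxy at this position, opposite the ring nitrogen, gives the first readable value for the series. From the compounds shown here alone, replacing carboxy with methoxy gives an at least 1.0-fold lower number from compound 2 to compound 3 (0.03 log units; that floor lies within the scatter), and replacing hydroxymethyl with methoxy gives an at least 1.0-fold lower number from compound 1 to compound 3 (0.03 log units; that floor lies within the scatter); as only a floor is known for each step, their true sizes stay open. The series still rests mostly on limits: the limit of > 100000 nM in this assay, at which 2 of the 3 values shown sit.

Going by these compounds, whether another group at this position would move the number clearly beyond the scatter remains open. An amine or a longer chain there could settle this, and the effect of changing the 4-chlorobenzyl group or the 2,6-difluoropyridin-3-yl group is also left open.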